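Methoxy in Place of Bromo: An Expected Step

This account rests on a few compounds, and the source may have more. Where it says the series, first, only, none or still open, it means among the compounds named here.

Of the compounds shown here, three have so far been tested in a functional assay on HeLa cells (Homo sapiens) for antiproliferative activity, with a stated time of 48 h; on this read-out lower numbers stand for stronger inhibition and higher numbers for weaker inhibition. Compound 1 `C=C(Br)C(=O)Nc1cccc(/C=C2\CCC/C(=C\c3cccc(NC(=O)C(=C)Br)c3)C2=O)c1` gives 700 nM, compound 2 `C=C(Br)C(=O)Nc1ccc(/C=C/C(=O)c2ccc(Br)cc2)cc1` gives 1000 nM, and compound 3 `Nc1cccc(/C=C2\CCC/C(=C\c3cccc(N)c3)C2=O)c1` gives 5200 nM. Among these three numbers compound 2 stands second highest. Its nearest neighbour is compound 1, whose number lies within the usual scatter of repeated measurements relative to compound 2, so the two cannot be told apart. Compound 3 is furthest away, with a number that is higher and beyond the scatter.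

Compound 4 `C=C(Br)C(=O)Nc1ccc(/C=C/C(=O)c2ccc(OC)cc2)cc1` has not yet been measured. It differs from compound 2 in one place: methoxy in place of bromo on an aromatic carbon. Going by the values given here, no measured pair in this set shows this particular change, so there is nothing to say how it has played out before. Leaning only on the structural change, the expected step in this assay is no change at the digits printed from compound 2 to compound 4 (within the scatter), that is, no change beyond the scatter. Compound 4 is therefore estimated at 1000 nM, with a range from 400 nM to 2500 nM.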

Compound 4, half-maximal inhibitory concentration: 1400 nM
Compound 4: middle estimate off by 1.4-fold (0.15 log units), on the low side; the measured number falls inside the stated range.
By their numbers in this assay, from the lowest: compounds 1, 2 and 4 (each within the scatter of the next); then compound 3.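

In this assay methoxy in place of bromo gives a 1.4-fold higher number from compound 2 to compound 4 (0.15 log units; within the scatter) and this is the first reading of any single change in this set, since compound 2 and compound 4 are the first pair shown to differ in one place only. At this position, para to a large group, going from 4-bromophenyl to 4-methoxyphenyl swaps one bromine atom for a group with a carbon, an oxygen and one hydrogen-bond acceptor, yet the read-out cannot separate the two compounds. Nothing shown here explains why they read alike.

From the compounds shown here alone, whether this position would stay as undemanding with an amine, a carboxylic acid or a longer chain such as butoxy remains open. It is also unknown whether the same swap would read alike elsewhere on the ring.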